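Halogen swap at the benzoyl para position: compound 4

The source may report more compounds than this note shows. Statements on the series, on what has been measured and on what is new or still open speak of the compounds shown alone.

Compound 3 `CC(=O)O[C@@H]1[C@H]2OC(C)(C)O[C@H]2O[C@@H]1C(=O)c1cnc2sc(C(=O)c3ccc(Br)cc3)cn12` shares its core with compound 1 `CO[C@@H]1[C@H]2OC(C)(C)O[C@H]2O[C@@H]1C(=O)c1cnc2sc(C(=O)c3ccc(Cl)cc3)cn12` and compound 2 `CC(=O)O[C@@H]1[C@H]2OC(C)(C)O[C@H]2O[C@@H]1C(=O)c1cnc2sc(C(=O)c3ccccc3)cn12`. In an ADME assay on Vero cells (Chlorocebus sabaeus) for cytotoxicity, read by MTT assay, with a stated time of 48 h (on this read-out higher numbers stand for lower toxicity in this test and lower numbers for higher toxicity in this test), compound 3 gives 139000 nM, the lowest of the two numbers available; compound 1 gives 371000 nM, the nearest value. For compound 2 the result is a limit of the assay, > 400000 nM, and only that. The one single-point step shown, an at least 2.8-fold lower number from compound 2 to compound 3 (0.45 log units; beyond the scatter), comes from the limit of > 400000 nM in this assay, at which 1 of the 3 values shown sits, and sets a floor on that change rather than a number.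

Compound 4 `CC(=O)O[C@@H]1[C@H]2OC(C)(C)O[C@H]2O[C@@H]1C(=O)c1cnc2sc(C(=O)c3ccc(Cl)cc3)cn12` differs from compound 3 by chloro in place of bromo on an aromatic carbon. Going by the values given here, no measured pair isolates this change; compound 1 also carries chloro but differs from compound 3 in a second place, so its value only shows where a chloro analogue of the series can sit. A halogen-for-halogen exchange is expected to move the number little, at most a modest rise toward the value of compound 1, a 1.7-fold higher number from compound 3 to compound 4 (0.22 log units; within the scatter). For compound 4 the estimate in this assay is therefore 230000 nM, within 110000 nM to 460000 nM.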

Compound 4, half-maximal cytotoxic concentration: 70000 nM
Beside the measured number, compound 4's estimate is 3.3-fold (0.52 log units) above it; measured number outside the range, below it.
By their numbers in this assay, from the lowest: compounds 4 and 3 (each within the scatter of the next); then compound 1. At a limit, above all of these: compound 2.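

In this assay, a 2.0-fold lower number from compound 3 to compound 4 (0.30 log units; within the scatter), so chloro and bromo at this position cannot be told apart. Compound 2 stands at a limit, which makes an at least 5.7-fold lower number from compound 2 to compound 4 (0.75 log units; beyond the scatter) a floor for chloro in place of hydrogen rather than a size: the limit of > 400000 nM in this assay, at which 1 of the 4 values shown sits. The series also responds at a second place: with chloro held constant, acetyl in place of methyl on the oxygen gives a 5.3-fold lower number from compound 1 to compound 4 (0.72 log units; beyond the scatter), a step beyond the scatter, unlike the halogen exchange.

Still open, going by these compounds, is whether fluoro, methoxy or an amine on this aromatic carbon would fall with chloro and bromo or with hydrogen. Also open, on these data alone, is whether the step from methyl to acetyl on the oxygen holds with bromo or hydrogen on the ring.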